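The source may report more compounds than this note shows. Statements on the series, on what has been measured and on what is new or still open speak of the compounds shown alone.

Notes on the series. Of the compounds shown here, three have been measured in a functional assay on cells (Cancer cell lines, Homo sapiens) for cytotoxicity, with a stated time of 48 h; on this read-out higher numbers stand for weaker inhibition of growth and lower numbers for stronger inhibition of growth. Compound 1 `COc1cc2c(/C=C3/C(=O)Nc4ccc(Cl)cc43)c(Cl)n(Cc3cc(OC)c(OC)c(OC)c3)c2cc1C` gives 2190 nM in this assay; compound 2 `O=C1/C(=C/c2c(Cl)[nH]c3ccccc23)c2ccccc2N1Cc1ccccc1` gives 4170 nM; compound 3 `COc1c(/C=C2/C(=O)Nc3ccccc32)c2ccccc2n1-c1ccccc1` gives 1050 nM. On these numbers compound 3 stands lowest of the three: the nearest is compound 1, and the gap to compound 1 as well as the larger gap to compound 2 lies beyond the scatter, so compound 3 is the most potent of the measured set. Within the data shown here, no two of the measured compounds differ in one place only, so no single step between them is available.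

Compound 4 `COc1c(/C=C2/C(=O)Nc3ccc(Cl)cc32)c2ccccc2n1-c1ccccc1` has not been measured. It differs from compound 3 by chloro in place of hydrogen on an aromatic carbon, meta to a fused ring and para to a fused ring of that two-ring system. Compound 1 carries a chloro at the same ring but differs in several other places as well, so the value of compound 1, 2190 nM, does not isolate the chloro. The expected step in this assay from compound 3 to compound 4 is small, a 1.3-fold lower number from compound 3 to compound 4 (0.12 log units; within the scatter), not beyond the scatter. Compound 4 is estimated at 800 nM, with a range from 350 nM to 2500 nM.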

Compound 4, concentration for 50% growth inhibition: 6310 nM
Compound 4: middle estimate off by 7.9-fold (0.90 log units), on the low side; measured number outside the range, above it.
By their numbers in this assay, from the lowest: compound 3; then compounds 1, 2 and 4 (each within the scatter of the next, the first and the last beyond it).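

In this assay chloro in place of hydrogen on this aromatic carbon, meta to a fused ring and para to a fused ring, gives a 6.0-fold higher number from compound 3 to compound 4 (0.78 log units; beyond the scatter) and so weaker inhibition of growth, which shows that this position is sensitive to the addition of a single heavy atom. Compound 1 also carries a chloro on this ring, but its other differences had left the contribution of this change unresolved, and the pair of compound 3 and compound 4 now isolates it. Nothing at hand gives a reason for this loss of potency.

On these data alone, it remains open whether the loss is specific to chloro or extends to other groups at this carbon, such as fluoro or an amine. As far as these compounds go, it also remains open whether the same step would appear on the cores of compound 1 and compound 2.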